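Swapping a Methyl for an Amide on the Ring Nitrogen

This account rests on a few compounds, and the source may have more. Where it says the series, first, only, none or still open, it means among the compounds named here.

Of the compounds shown here, three sharing one core have been tested in an assay on HEK293 cells for negative allosteric modulation of metabotropic glutamate receptor 5 (Homo sapiens), read by FLIPR, with a stated time of 1 h (on this read-out lower numbers stand for stronger inhibition and higher numbers for weaker inhibition), so far. Compound 1 `O=C1NCCc2nc(C#Cc3ccccc3F)sc21` gives only a limit, > 10000 nM, rather than a number. Compound 2 `CN1CCc2nc(C#Cc3ccccc3)sc2C1` likewise reaches only a limit, > 10000 nM. Compound 3 `CC(=O)N1CCc2nc(C#Cc3ccccc3)sc2C1` gives a real number, 90 nM. Where compound 2 stands is therefore only known as the limit of > 10000 nM in this assay, at which 2 of the 3 values shown sit, which means no precise potency is available for it, only the knowledge that it is weak.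

The unmeasured compound 4 `O=C(C1CC(F)C1)N1CCc2nc(C#Cc3ccccc3)sc2C1` differs from compound 2 in one place: (3-fluorocyclobutyl)carbonyl in place of methyl on an amine nitrogen in a ring. Among the measured compounds shown here, only one measured step bears on this change. The move from methyl to acetyl on the same ring nitrogen gave an at least 110-fold lower number from compound 2 to compound 3 (2.04 log units; beyond the scatter), a large gain. As far as these compounds go, compound 4 keeps the carbonyl of that acetyl and extends it with a (3-fluorocyclobutyl) group, so the same kind of large step toward a lower number is expected in this assay, though how much the added ring shifts it is unknown.

Compound 4 is therefore estimated to give about 60 nM, with a plausible range from 15 nM to 300 nM, corresponding to an expected step of an at least 160-fold lower number from compound 2 to compound 4 (2.22 log units; beyond the scatter).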

Compound 4, half-maximal inhibitory concentration: > 10000 nM
Compound 4 ended at the assay's limit; the forecaster's own chance of this, stated with the estimate: 5%; middle value at least 160-fold (2.22 log units) away from the limit.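

In this assay, keeping a carbonyl on the ring nitrogen proves not to be enough: putting 3-fluorocyclobutyl in place of the methyl on the carbonyl carbon gives an at least 110-fold higher number from compound 3 to compound 4 (2.04 log units; beyond the scatter). Compound 2 and compound 4 each stand at a limit rather than at a number, so the step between them cannot be read, and the two can only be grouped together as weak: the limit of > 10000 nM in this assay, at which 3 of the 4 values shown sit. Of the three compounds that differ only on this ring nitrogen, compound 3 alone gives a real number, which shows that what is attached to the carbonyl matters as well as the carbonyl itself.

The compounds shown leave open whether the loss belongs to the four-membered ring or to the fluorine on it, a question that a plain cyclobutylcarbonyl group on the same nitrogen would help to settle. They also leave open how far the acetyl can be changed before activity is lost, and a propionyl or a cyclopropylcarbonyl group would begin to map that range.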